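This account rests on a few compounds, and the source may have more. Where it says the series, first, only, none or still open, it means among the compounds named here.

Series measured in a functional assay on HeLa cells (Homo sapiens) for antiproliferative activity, read by MTT assay, with a stated time of 48 h; on this read-out higher numbers stand for weaker inhibition and lower numbers for stronger inhibition:

- compound 1 `CCOc1cc(-c2ccc3cc[nH]c3c2)cn2c(-c3cc(OC)c(OC)c(OC)c3)nnc12`: 272 nM
- compound 2 `COc1cc(-c2nnc3c(OC)cc(-c4ccc5[nH]ccc5c4)cn23)cc(OC)c1OC`: 85 nM
- compound 3 `COc1cc(-c2nnc3c(OC(C)C)cc(-c4ccc5[nH]ccc5c4)cn23)cc(OC)c1OC`: 261 nM

Compound 3 cannot be separated from compound 1 within the scatter, and both numbers lie beyond the scatter from that of compound 2. Next is compound 4 `COc1cc(-c2nnc3c(OCC(F)(F)F)cc(-c4ccc5[nH]ccc5c4)cn23)cc(OC)c1OC`, with 2,2,2-trifluoroethyl in place of isopropyl on an oxygen on an aromatic ring. Going by the values given here, one measured step bears on this change, a modest one at the same place: a 3.1-fold higher number from compound 2 to compound 3 (0.49 log units; beyond the scatter). Among the compounds with values here, no measured compound carries a fluorinated chain, so that step sets the likely size but gives no direction, and no shift beyond the scatter is expected in this assay. The expected change is a 1.0-fold lower number from compound 3 to compound 4 (0.02 log units; within the scatter). The estimate for compound 4 is 250 nM, with an expected range of 90 nM to 700 nM.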

Compound 4, half-maximal inhibitory concentration: 348 nM
Estimate against measurement, compound 4: 1.4-fold (0.14 log units) below, within the range that was stated.
By their numbers in this assay, from the lowest: compound 2; then compounds 3, 1 and 4 (each within the scatter of the next).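

In this assay the step of a 1.3-fold higher number from compound 3 to compound 4 (0.12 log units; within the scatter) shows that 2,2,2-trifluoroethyl on this oxygen cannot be told apart from isopropyl. The step of a 4.1-fold higher number from compound 2 to compound 4 (0.61 log units; beyond the scatter) sets this fluorinated chain apart from methyl as well, so among compounds 2, 3 and 4 only the methyl ether of compound 2 stands at the low end of the numbers. As far as these compounds go, whether an aminoethyl chain, a longer chain or a free hydroxyl at this place would match or pass methyl stays open. Nothing shown gives a cause for these steps.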